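Acyl in Place of Ring Nitrogen Hydrogen

The source may hold more compounds than are shown below. What is called first, only, known or untested is meant among the compounds shown, and "the series" means these compounds.

Measured so far:
compound 1 `Cc1[nH]nc(N)c1-c1ccc(Cl)c(Cl)c1`: > 100000 nM
compound 2 `Cc1[nH]nc(N)c1-c1cccc(Cl)c1`: 93400 nM

In an assay on Sf9 cells for inhibition of inhibitor of nuclear factor kappa-B kinase subunit epsilon (Homo sapiens), read by ADP-Glo, with a stated time of 60 min (on this read-out lower numbers stand for stronger inhibition and higher numbers for weaker inhibition), compound 1 gives > 100000 nM, which is a limit of the assay and not a number. In this assay compound 2 gives 93400 nM. Within the data shown here, the only measured step, an at least 1.0-fold lower number from compound 1 to compound 2 (0.02 log units; that floor lies within the scatter), exchanges a chloro for hydrogen on an aromatic carbon and leaves the ring nitrogen untouched. Compound 3 `Cc1c(-c2ccc(Cl)c(Cl)c2)c(N)nn1C(=O)C1CCC1` differs from compound 1 by cyclobutylcarbonyl in place of hydrogen on an aromatic nitrogen. Among the measured compounds shown here, no measured step bears on this change, so no shift beyond the scatter is expected from the limit of compound 1. Compound 3 is therefore estimated at 80000 nM, ranging from 20000 nM to 300000 nM. That estimate means an expected step of an at least 1.2-fold lower number from compound 1 to compound 3 (0.09 log units; that floor lies within the scatter).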

Compound 3, half-maximal inhibitory concentration: > 100000 nM
Compound 3 was reported as a limit; the forecaster's own chance of this, stated with the estimate: 50%; middle value at least 1.2-fold (0.09 log units) from the limit.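

Among these compounds, no step from compound 1 to compound 3 can be read, since both stand at the same limit of the assay, which is not a number: the limit of > 100000 nM in this assay, at which 2 of the 3 values shown sit. Going by these compounds, how far cyclobutylcarbonyl in place of hydrogen on an aromatic nitrogen shifts the read-out stays open.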